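Methoxy for methylsulfanyl in a series at its limit

The source may hold more compounds than are shown below. What is called first, only, known or untested is meant among the compounds shown, and "the series" means these compounds.

Measured in a functional assay on A549 cells (Homo sapiens) for cytotoxicity, read by MTT assay, with a stated time of 48 h; a lower number here means a stronger inhibitor, a higher number a weaker inhibitor:
- compound 1 `COc1cc(-c2ocnc2-c2cc(Br)c(OC)c(OC)c2)ccc1SC`: > 20000 nM
- compound 2 `COc1cc(-c2ocnc2-c2cc(OC)c(OC)c(OC)c2)ccc1SC`: > 20000 nM
- compound 3 `COc1ccc(-c2c(-c3cc(Br)c(OC)c(OC)c3)ncn2C)cc1SC`: > 20000 nM

Compound 1 gives only a limit, > 20000 nM, not a number. The other two entries are limits as well, so the whole set stands at the limit of > 20000 nM in this assay, at which 3 of the 3 values shown sit.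

Compound 4 `COc1ccc(-c2ocnc2-c2cc(Br)c(OC)c(OC)c2)cc1OC` is not yet measured. Its difference from compound 1 is methoxy in place of methylsulfanyl on an aromatic carbon.

Going by the values given here, the one measured step is a step that the two limits leave unreadable from compound 1 to compound 2. Among the compounds with values here, it concerns methoxy in place of bromo, and no measured step covers methoxy in place of methylsulfanyl. No shift beyond the usual scatter is therefore expected in this assay, and no direction can be argued. The expected step is a step that the limit leaves unreadable from compound 1 to compound 4. Compound 4 is estimated at 30000 nM, with an expected range of 12000 nM to 80000 nM.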

Compound 4, half-maximal inhibitory concentration: 500 nM
Estimate against measurement, compound 4: 60-fold (1.78 log units) above; the measured number lies below the stated range.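

In this assay, methoxy in place of methylsulfanyl on this aromatic carbon gives an at least 40-fold lower number from compound 1 to compound 4 (1.60 log units; beyond the scatter). The value of compound 1, > 20000 nM, is a limit. The two groups differ only in sulfur against oxygen, and that single atom separates compound 4, the only measured number in the set, from the rest: the limit of > 20000 nM in this assay, at which 3 of the 4 values shown sit.

Still open, from the compounds shown here alone, is how a hydroxyl, an ethoxy or an amine on this carbon would read in this assay. Also open, going by these compounds, is whether methoxy here would lift compound 2 or compound 3 off their limits.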